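Swapping ethylamino for dimethylamino on a carbonyl carbon

The source may report more compounds than this note shows. Statements on the series, on what has been measured and on what is new or still open speak of the compounds shown alone.

Compound 1 `CNC(=O)c1cc(Oc2ccc3c(C)c(C(=O)OC(C)C)sc3c2)ccn1`: 18100 nM
Compound 2 `CNC(=O)c1cc(Oc2ccc3c(C)c(C(=O)O)sc3c2)ccn1`: > 100000 nM (a limit)
Compound 3 `CCNC(=O)c1sc2cc(Oc3ccnc(C(=O)NC)c3)ccc2c1C`: > 100000 nM (a limit)

These values come from an ADME assay on H1-HeLa cells (Homo sapiens) for cytotoxicity, read by MTT assay, with a stated time of 3 days; on this read-out higher numbers stand for lower toxicity in this test and lower numbers for higher toxicity in this test. Compound 3 gives > 100000 nM, which is a limit of the assay and not a number. That is the limit of > 100000 nM in this assay, at which 2 of the 3 values shown sit.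

Compound 4 `CNC(=O)c1cc(Oc2ccc3c(C)c(C(=O)N(C)C)sc3c2)ccn1` is compound 3 with one change, dimethylamino in place of ethylamino on a carbonyl carbon.

Going by the values given here, two measured steps bear on this change. The closer one is an at least 5.5-fold higher number from compound 1 to compound 3 (0.74 log units; beyond the scatter), with ethylamino in place of isopropoxy. The other is an at least 5.5-fold higher number from compound 1 to compound 2 (0.74 log units; beyond the scatter), with hydrogen in place of isopropyl. Among the compounds with values here, both lie beyond the scatter, and both start from the only compound with a true number. The third is a step that the two limits leave unreadable from compound 2 to compound 3. Within the data shown here, no measured step swaps one amino group for another on that carbonyl carbon.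

The expected step is a number no higher from compound 3 to compound 4 (the limit leaves the size open), which means no change beyond the scatter in this assay. The estimate for compound 4 is 100000 nM, with an expected range of 40000 nM to 200000 nM.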

Compound 4, half-maximal cytotoxic concentration: 42500 nM
Beside the measured number, compound 4's estimate is 2.4-fold (0.37 log units) above it; the measured number falls inside the stated range.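

In this assay, dimethylamino in place of ethylamino on this carbonyl carbon, which removes the group's one hydrogen-bond donor, gives an at least 2.3-fold lower number from compound 3 to compound 4 (0.37 log units; beyond the scatter), so two amino groups with the same heavy atoms do not read alike here. Dimethylamino in place of hydroxy gives an at least 2.3-fold lower number from compound 2 to compound 4 (0.37 log units; beyond the scatter), and dimethylamino in place of isopropoxy gives a 2.3-fold higher number from compound 1 to compound 4 (0.37 log units; beyond the scatter), so on this read-out dimethylamino gives a lower number than ethylamino or hydroxy and a higher one than isopropoxy. The first two of these steps start from limits of the assay, not numbers, so they give only a minimum size: the limit of > 100000 nM in this assay, at which 2 of the 4 values shown sit.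

On these data alone, it stays open whether the lower number follows the loss of the amide hydrogen, which a methylamino or plain amino group on the same carbonyl carbon could help to separate. As far as these compounds go, how a longer chain such as propylamino would read is also open, and the step from compound 2 to compound 3 cannot be read.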